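Aryl substituent variation in the lactam acid series: compound 4

A few compounds are considered here, and "the series" means these few. Any claim that something is new, unique, unknown or untested is made for them only; others in the source may bear on it.

The shared core carries a heptanoic acid chain on the lactam nitrogen in compounds 2 and 3, while compound 1 `O=C(O)c1ccc(CCCN2C(=O)CCC2CCC(O)Cc2cccc(Cl)c2)cc1` has a benzoic acid chain and gives 425 nM in a functional assay on HEK293 cells with prostaglandin E2 receptor EP4 subtype (Rattus norvegicus) as the target, read by cAMP accumulation; on this read-out lower numbers stand for an effect already at smaller amounts and higher numbers for an effect only at larger amounts of compound. Compound 2 `O=C(O)CCCCCCN1C(=O)CC[C@@H]1CC[C@@H](O)Cc1cccc(-c2ccccc2)c1` gives 195 nM. Compound 3 `N#Cc1cccc(C[C@H](O)CC[C@H]2CCC(=O)N2CCCCCCC(=O)O)c1` gives 96 nM, the lowest of the three numbers; the nearest is compound 2 and the furthest compound 1, both beyond the scatter. Among the compounds with values here, the only single-point step measured is a 2.0-fold lower number from compound 2 to compound 3 (0.31 log units; beyond the scatter), cyano in place of phenyl on an aromatic carbon.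

Compound 4 `O=C(O)CCCCCCN1C(=O)CC[C@@H]1CC[C@@H](O)Cc1cccc(OC(F)(F)F)c1` differs from compound 3 by trifluoromethoxy in place of cyano on an aromatic carbon. The step from compound 2 to compound 3 bears on the same aromatic carbon, yet neither of its groups is the one entering here, so it sets only the scale: a change at this position moved the number modestly. Compound 1, with chloro at the same place, gives a higher number, but differs in chain and stereochemistry as well, so it carries little weight. The step for compound 4 is therefore expected to be modest, more likely upward, a 2.1-fold higher number from compound 3 to compound 4 (0.32 log units; beyond the scatter). Compound 4 is expected to give about 200 nM in this assay, within 70 nM to 600 nM.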

Compound 4, half-maximal effective concentration: 50 nM
Compound 4: the middle estimate sits 4.0-fold (0.60 log units) above what was measured; the measured number lies below the stated range.
By their numbers in this assay, from the lowest: compounds 4 and 3 (each within the scatter of the next); then compound 2; then compound 1.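

In this assay the exchange of cyano for trifluoromethoxy on this aromatic carbon gives a 1.9-fold lower number from compound 3 to compound 4 (0.28 log units; within the scatter), so these two groups cannot be ranked here, although they share no atoms beyond a single carbon and differ in size by the heavy-atom counts. Phenyl now stands apart from both, with a 2.0-fold lower number from compound 2 to compound 3 (0.31 log units; beyond the scatter) and a 3.9-fold lower number from compound 2 to compound 4 (0.59 log units; beyond the scatter), and within these three compounds with the heptanoic acid chain neither replacement goes against that reading; compound 1 differs in more than one place and does not enter the comparison. No accompanying data bear on this result, and the separation from phenyl stays without an explanation.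

Open, from the compounds shown here alone, is whether the lower numbers extend to other groups on the same aromatic carbon, such as methoxy, trifluoromethyl or a plain hydrogen, which would show whether phenyl is the exception or cyano and trifluoromethoxy are. Also open, going by these compounds, is whether trifluoromethoxy holds its place when the heptanoic acid chain is replaced by the benzoic acid chain of compound 1.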